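Replacing a Ring with an Open Chain

The source may report more compounds than this note shows. Statements on the series, on what has been measured and on what is new or still open speak of the compounds shown alone.

Values in a functional assay on HepG2 cells (Homo sapiens) for inhibition, read by MTT assay, with a stated time of 72 h; a higher number here means a weaker inhibitor, a lower number a stronger inhibitor:
- compound 1 `O=C(/C=C/c1ccc(CN(Cc2ccc(F)cc2)c2ncc(C(=O)NCCCn3ccnc3)s2)cc1)NO`: 13000 nM
- compound 2 `O=C(CCCCCN(Cc1ccc(F)cc1)c1ncc(C(=O)NCCCn2ccnc2)s1)NO`: 30000 nM
- compound 3 `O=C(NO)c1ccc(CN(Cc2ccc(F)cc2)c2ncc(C(=O)NCCCn3ccnc3)s2)cc1`: 79000 nM

Of these three, compound 3 has the highest number, at 79000 nM, which makes it the weakest inhibitor. Compound 4 `O=C(CCCCCCN(Cc1ccc(F)cc1)c1ncc(C(=O)NCCCn2ccnc2)s1)NO` differs from it as follows: 5-(hydroxycarbamoyl)pentyl in place of 4-(hydroxycarbamoyl)phenyl on a saturated chain carbon bound to a nitrogen on an aromatic ring. Here 5-(hydroxycarbamoyl)pentyl replaces 4-(hydroxycarbamoyl)phenyl on a saturated chain carbon bound to a nitrogen on an aromatic ring. Compound 2 also has an open chain in that place. The closest measured change, a 2.6-fold higher number from compound 2 to compound 3 (0.42 log units; beyond the scatter), went from chain to ring, so the reverse change here should give a lower number by a similar, modest amount. The expected move is a 2.8-fold lower number from compound 3 to compound 4 (0.45 log units; beyond the scatter). For compound 4 the estimated value in this assay is 28000 nM, with an expected range of 10000 nM to 75000 nM.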

Compound 4, half-maximal inhibitory concentration: 9400 nM
For compound 4 the middle estimate is 3.0-fold (0.47 log units) above the measured one; measured number below the stated range.
By their numbers in this assay, from the lowest: compounds 4 and 1 (each within the scatter of the next); then compound 2; then compound 3.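

In this assay, swapping the ring for an open chain pays off more here than the earlier chain-and-ring pair showed: an 8.4-fold lower number from compound 3 to compound 4 (0.92 log units; beyond the scatter). Chain length also counts at this position, since 5-(hydroxycarbamoyl)pentyl in place of 4-(hydroxycarbamoyl)butyl gives a 3.2-fold lower number from compound 2 to compound 4 (0.50 log units; beyond the scatter). The ring is not needed to reach the level of the best ring-bearing compound shown, with a 1.4-fold lower number from compound 1 to compound 4 (0.14 log units; within the scatter). On these data alone, whether a still longer chain would lower the number further stays open. No measurement shown explains these shifts.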